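From cyclopentyl to cyclooctyl on the amide nitrogen

This account rests on a few compounds, and the source may have more. Where it says the series, first, only, none or still open, it means among the compounds named here.

Values in a functional assay on MIA PaCa-2 cells (Homo sapiens) for cytotoxicity, read by fluorescence, with a stated time of 48 h; a lower number here means that less compound is needed, a higher number that more compound is needed for the effect:
Compound 1 `CC(C)=CCC/C(C)=C/CC/C(C)=C/CSC[C@H](NC(=O)CCCCCN1CCCC1)C(=O)NC1CCCCC1`: 5600 nM
Compound 2 `CC(C)=CCC/C(C)=C/CC/C(C)=C/CSC[C@H](NC(=O)CCCCCN1CCCC1)C(=O)NC1CCCC1`: 3200 nM

Compound 2 lies within the scatter of compound 1, so these two values cannot be ranked. Compound 3 `CC(C)=CCC/C(C)=C/CC/C(C)=C/CSC[C@H](NC(=O)CCCCCN1CCCC1)C(=O)NC1CCCCCCC1`, not yet measured, has cyclooctyl in place of cyclopentyl on an amide-type nitrogen. Going by the values given here, only one measured step bears on this change: a 1.8-fold lower number from compound 1 to compound 2 (0.24 log units; within the scatter), with cyclopentyl in place of cyclohexyl at the same place. Among the compounds with values here, that step stays within the scatter, but no measured compound carries a ring as large as cyclooctyl, so the reach of this evidence is limited. No step beyond the scatter is therefore expected in this assay. The estimated step is a 1.4-fold higher number from compound 2 to compound 3 (0.15 log units; within the scatter). Compound 3 is expected at about 4500 nM, with an estimated range of 1800 nM to 11000 nM.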

Compound 3, half-maximal effective concentration: 1900 nM
Compound 3: middle estimate off by 2.4-fold (0.37 log units), on the high side; the measured number falls inside the stated range.
By their numbers in this assay, from the lowest: compounds 3, 2 and 1 (each within the scatter of the next, the first and the last beyond it).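

In this assay the step from cyclopentyl to cyclooctyl on the amide-type nitrogen is a 1.7-fold lower number from compound 2 to compound 3 (0.23 log units; within the scatter) and leaves these two rings unranked. Set against cyclohexyl, cyclooctyl gives a 2.9-fold lower number from compound 1 to compound 3 (0.47 log units; beyond the scatter) and so provides the first step at this position that passes beyond the scatter, though a modest one. An eight-membered ring is therefore accepted on this nitrogen, yet only the cyclohexyl and cyclooctyl compounds can be told apart, while cyclopentyl cannot be separated from either.

As far as these compounds go, whether a ring larger than cyclooctyl, an open-chain group such as tert-butyl, or a cyclohexyl ring carrying an amine would keep the number in this range remains open. Nothing shown offers a reason for these differences.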